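From Trifluoromethyl to Carbamoyl: a Trypsin Step Foreseen

The compounds below may be only part of what the source reports. "The series", "measured", "known", "first", "only" and "open" are said of these compounds alone.

Of the compounds shown here, three of a shared core have been measured in an assay on isolated protein for inhibition of Trypsin (Homo sapiens); a lower number here means a stronger inhibitor, a higher number a weaker inhibitor. Compound 1 `Cc1nn(-c2cccc(CN)c2)c2c(F)c(-c3ccc(N4CCCCC4=O)cc3)ccc12` gives 1900 nM. Compound 2 `Cc1nn(-c2ccc3onc(N)c3c2)c2c(F)c(-c3ccc(N4CCCCC4=O)cc3F)ccc12` shows only a limit, > 10000 nM. Compound 3 `Nc1noc2ccc(-n3nc(C(F)(F)F)c4ccc(-c5ccc(N6CCCCC6=O)cc5F)c(F)c43)cc12` likewise shows only a limit, > 10000 nM. The step that the two limits leave unreadable from compound 2 to compound 3 cannot be sized because of the limit of > 10000 nM in this assay, at which 2 of the 3 values shown sit. Compound 4 `NC(=O)c1nn(-c2ccc3onc(N)c3c2)c2c(F)c(-c3ccc(N4CCCCC4=O)cc3F)ccc12` is not yet measured; it differs from compound 3 by carbamoyl in place of trifluoromethyl on an aromatic carbon. Among the measured compounds shown here, no measured step bears directly on this change, and the only measured step that involves compound 3 is unreadable, so the data give no direction in this assay beyond a likely stay at the limit. Compound 4 is expected to sit near 12000 nM, within 3000 nM to 50000 nM. This estimate means a step that the limit leaves unreadable from compound 3 to compound 4 that is expected to lie within the scatter.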

Compound 4, inhibition constant: > 10000 nM
Compound 4: no number, only a limit (the forecaster's own chance of this, stated with the estimate: 70%); the middle value does not contradict the limit.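

Compound 4 shows only a limit, so the steps to it from compound 2 and compound 3 cannot be read. The compounds shown leave open how carbamoyl, methyl and trifluoromethyl compare in this assay on the shared core.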